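The source may report more compounds than this note shows. Statements on the series, on what has been measured and on what is new or still open speak of the compounds shown alone.

Measured compounds:
- compound 1 `CC(C)(C)c1ccc(C(=O)N2CCC3(CC2)C(=O)N(CC(=O)N2CCC(CCO)CC2)CN3c2ccccc2)cc1`, in an assay on HEK293 cells for displacement of a labelled ligand from NPC1-like intracellular cholesterol transporter 1 (Homo sapiens) (on this read-out lower numbers stand for stronger inhibition and higher numbers for weaker inhibition), compound 1 gives 2600 nM
- compound 2 `CC1(C)CC(OC(=O)CN2CN(c3ccccc3)C3(CCN(C(=O)c4ccc(C(C)(C)C)cc4)CC3)C2=O)CC(C)(C)N1`, in this assay compound 2 gives 1300 nM
- compound 3 `COC(=O)CCCNC(=O)CN1CN(c2ccccc2)C2(CCN(C(=O)c3ccc(C(C)(C)C)cc3)CC2)C1=O`, in this assay compound 3 gives "not determined" (no result reported)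

All three share one core; they differ only in the group attached to the carbonyl carbon of the side chain. For the measured compounds named here, the single step among numbered results, a 2.0-fold lower number from compound 1 to compound 2 (0.30 log units; within the scatter), is within the scatter, so exchanging one amine-bearing group for another at that position has so far left the read-out essentially unchanged. Compound 3 stands nowhere on the numbers: no result was reported for it, so it gives no anchor.

Compound 4 `CCOC(=O)C1CCN(C(=O)CN2CN(c3ccccc3)C3(CCN(C(=O)c4ccc(C(C)(C)C)cc4)CC3)C2=O)CC1` is not yet measured. Its change from compound 3 is 4-(ethoxycarbonyl)piperidin-1-yl in place of (3-(methoxycarbonyl)propyl)amino on a carbonyl carbon. Going by the values given here, no measured step covers this exact exchange, yet compound 4 closely resembles compound 1 in carrying a piperidine ring on that carbonyl carbon, and the step from compound 1 to compound 2 suggests this position tolerates such exchanges without a shift beyond the scatter. Compound 4 is therefore expected to lie near compounds 1 and 2, at about 2000 nM, with a range from 600 nM to 7000 nM.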

Compound 4, half-maximal inhibitory concentration: 3100 nM
The estimate for compound 4 lay 1.6-fold (0.19 log units) below the measured number, within the range that was stated.
By their numbers in this assay, from the lowest: compounds 2, 1 and 4 (each within the scatter of the next, the first and the last beyond it).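

The exchange of 2-hydroxyethyl for ethoxycarbonyl on a saturated ring carbon gives a 1.2-fold higher number from compound 1 to compound 4 (0.08 log units; within the scatter) in this assay and so leaves the read-out unchanged, which shows that these two substituents on the piperidine ring cannot be told apart here. For the compounds shown here, replacing (2,2,6,6-tetramethylpiperidin-4-yl)oxy with 4-(ethoxycarbonyl)piperidin-1-yl on the carbonyl carbon gives a 2.4-fold higher number from compound 2 to compound 4 (0.38 log units; beyond the scatter) and is the only step so far beyond the scatter, though it is modest, and compound 1 lies within the scatter of both other compounds. Nothing available explains these small differences.

Compound 3 has no number, so the open-chain (3-(methoxycarbonyl)propyl)amino group cannot be compared with the ring-bearing groups. On these data alone, whether a carboxylic acid or a primary amine on the piperidine ring would shift the read-out further remains open.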